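Three analogues and one untested compound in a cell assay

The source may report more compounds than this note shows. Statements on the series, on what has been measured and on what is new or still open speak of the compounds shown alone.

Compound 3 `O=C(Nc1cccc(-n2cc(-c3ccncc3)c(-c3ccc(Cl)c(O)c3)n2)c1)Nc1ccc(Cl)c(Cl)c1` carries a 3,4-dichlorophenyl on an amide-type nitrogen and a hydroxy on the shared core. In a functional assay on OVCAR-5 cells (Homo sapiens) for inhibition, read by sulforhodamine B assay, with a stated time of 48 h (on this read-out higher numbers stand for lower toxicity in this test and lower numbers for higher toxicity in this test), compound 3 gives > 32500 nM, which is a limit of the assay and not a number. Compound 1 `O=C(Nc1cccc(-n2cc(-c3ccncc3)c(-c3ccc(Cl)c(O)c3)n2)c1)Nc1cccc(C(F)(F)F)c1` differs from it by 3-(trifluoromethyl)phenyl in place of 3,4-dichlorophenyl on an amide-type nitrogen. In this assay compound 1 gives > 32500 nM, again only a limit. The step that the two limits leave unreadable from compound 3 to compound 1 therefore cannot be sized, both values sitting at the limit of > 32500 nM in this assay, at which 2 of the 3 values shown sit. Compound 2 `COc1cc(-c2nn(-c3cccc(NC(=O)Nc4ccc(Cl)c(Cl)c4)c3)cc2-c2ccncc2)ccc1Cl` differs from compound 3 by methyl in place of hydrogen on an oxygen on an aromatic ring. In this assay compound 2 gives > 50000 nM, also a limit. The step that the two limits leave unreadable from compound 2 to compound 3 is likewise unreadable, with compound 2 at the limit of > 50000 nM in this assay, at which 1 of the 3 values shown sits. Compound 4 `COc1cc(-c2nn(-c3cccc(NC(=O)Nc4cccc(C(F)(F)F)c4)c3)cc2-c2ccncc2)ccc1Cl` has not yet been measured; it differs from compound 2 by 3-(trifluoromethyl)phenyl in place of 3,4-dichlorophenyl on an amide-type nitrogen, the same change as from compound 3 to compound 1, now made on the core of compound 2 rather than that of compound 3. For compound 4 in this assay a step that the limit leaves unreadable from compound 2 to compound 4 is expected, since compound 2 sits at the limit of > 50000 nM in this assay, at which 1 of the 3 values shown sits, and the same change elsewhere left both partners at a limit. Compound 4 is accordingly estimated at 60000 nM, between 20000 nM and 200000 nM.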

Compound 4, concentration lethal to 50% of the cells: > 50000 nM
Compound 4 gave a limit, no number; the forecaster's own chance of this, stated with the estimate: 85%; the middle value lies beyond the limit too.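

In this assay compound 4 gives > 50000 nM, which is a limit of the assay and not a number. Its steps from compound 2 and from compound 1 cannot be read, as all of these values are limits. The compounds shown leave open whether either exchange, on the amide-type nitrogen or on the oxygen, changes the read-out in this assay at all.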